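The compounds below may be only part of what the source reports. "The series", "measured", "known", "first", "only" and "open" are said of these compounds alone.

Compound 1 `CCCC(=O)Nc1ncc(-c2cccc(Cl)c2)c(-c2ccccc2)n1`: > 80%
Compound 2 `CC(C)CC(=O)Nc1ncc(-c2cccc(Cl)c2)c(-c2ccccc2)n1`: 56%
Compound 3 `CCCCNc1ncc(-c2cccc(Cl)c2)c(-c2ccccc2)n1`: 56%

Three compounds on one shared core were tested in an assay on CHO cells for displacement of a labelled ligand from adenosine receptor A1 (Homo sapiens), read by scintillation counting, with a stated time of 1 h, tested at 1 uM; on this read-out lower numbers stand for less inhibition and higher numbers for more inhibition at the one concentration tested (going by the name of the read-out). Compound 1 sits at the limit of > 80% in this assay, at which 1 of the 3 values shown sits, so its value > 80% is a limit of the assay rather than a number. Compound 2 differs from compound 1 in methyl in place of hydrogen on a saturated chain carbon bound to two saturated chain carbons, and this gave a number at least 24 percentage points lower from compound 1 to compound 2 (beyond the scatter). Compound 3 differs from compound 1 in butyl in place of propylcarbonyl on a nitrogen on an aromatic ring, giving a number at least 24 percentage points lower from compound 1 to compound 3 (beyond the scatter). Between the two amine-free and amide variants there is no change at the digits printed from compound 2 to compound 3 (within the scatter).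

Compound 4 `CC(C)CCNc1ncc(-c2cccc(Cl)c2)c(-c2ccccc2)n1` is not yet measured in this assay. It differs from compound 3 in methyl in place of hydrogen on a saturated chain carbon bound to two saturated chain carbons, the same change seen from compound 1 to compound 2. On the strength of a number at least 24 percentage points lower from compound 1 to compound 2 (beyond the scatter), a further downward step is expected, a number 18 percentage points lower from compound 3 to compound 4 (beyond the scatter). Compound 4 is therefore estimated at 38%, between 18% and 58%.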

Compound 4, a percentage reported as inhibition, at one concentration (the size of the read-out at that concentration, not a potency): 39%
Compound 4: the middle estimate sits 1 percentage points below what was measured; the range from low to high includes it.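

In this assay, the same added methyl lowered the number on a second core, a number 17 percentage points lower from compound 3 to compound 4 (beyond the scatter), so the direction of the change carried over from one core to the other: the same change on two cores in this assay, a number at least 24 percentage points lower (beyond the scatter) from compound 1 to compound 2 and a number 17 percentage points lower (beyond the scatter) from compound 3 to compound 4; the limit leaves it open whether they differ Compound 1 gives > 80%, which is a limit and not a number, so this pair of cores does not show whether the size of the change carries over as well. The steps of a number 17 percentage points lower from compound 2 to compound 4 (beyond the scatter) and a number at least 41 percentage points lower from compound 1 to compound 4 (beyond the scatter) replace the whole carbonyl-bearing chain on the nitrogen with isopentyl, so they do not isolate the effect of the methyl.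

The compounds shown leave open whether a longer chain or a cyclopropyl group at the end of the chain would follow the same direction. They also leave open whether the change would carry to a core with another group on the nitrogen, such as a sulfonamide.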